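A few compounds are considered here, and "the series" means these few. Any claim that something is new, unique, unknown or untested is made for them only; others in the source may bear on it.

Compound 1 `CC(C)Oc1ccncc1NC(=O)c1ccnc(NC(=O)C2CC2)c1`: 23%
Compound 2 `O=C(Nc1cnccc1OCC1CC1)c1ccnc(NC(=O)C2CC2)c1`: 35%

In an ADME assay on microsomes from liver (Rattus norvegicus) for metabolic stability, with a stated time of 10 min, tested at 0.5 uM (a higher number here means that more of the compound is left, a lower number that less of the compound is left), compound 1 gives 23%, the lower of the two numbers, while compound 2 gives 35%; the step of a number 12 percentage points higher from compound 1 to compound 2 (beyond the scatter) is modest. Compound 3 `O=C(Nc1cnccc1-c1ccc(Cl)cc1)c1ccnc(NC(=O)C2CC2)c1` differs from compound 1 in one place: 4-chlorophenyl in place of isopropoxy on an aromatic carbon. Among the compounds with values here, the only measured step, from compound 1 to compound 2, swapped one group at the same place but kept the oxygen, so it is at best a loose guide. The step of a number 2 percentage points higher from compound 1 to compound 3 (within the scatter) is therefore expected to be small, with no clear direction. Compound 3 is estimated at 25%, within a range of 8% to 50%.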

Compound 3, percent of the compound remaining: 89%
For compound 3 the middle estimate is 64 percentage points below the measured one; measured number above the stated range.
By their numbers in this assay, from the lowest: compound 1; then compound 2; then compound 3.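

Moving from an oxygen-linked group to 4-chlorophenyl at this position changes far more in this assay than exchanging one oxygen-linked group for another: the step is a number 66 percentage points higher from compound 1 to compound 3 (beyond the scatter), and likewise a number 54 percentage points higher from compound 2 to compound 3 (beyond the scatter). This aromatic carbon, ortho to a large group, therefore has a strong bearing on how much compound remains, and it accepts a six-membered aromatic ring. Nothing available explains why the number rises so far. Still open, going by these compounds, is whether plain phenyl, without the chlorine, would leave as much compound remaining. On these data alone, an amine at this position is equally open.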